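Exchanging the amide substituent for a cyanoethyl methyl amide

This account rests on a few compounds, and the source may have more. Where it says the series, first, only, none or still open, it means among the compounds named here.

Compound 1, `CC[C@@H](C)[C@H](NC(=O)c1ccc(C(CC)(CC)c2ccc(OCC(=O)C(C)(C)C)c(C)c2)n1CC)C(=O)OC`, gives 590 nM in an assay on HL-60 cells for agonist activity at vitamin D3 receptor (Homo sapiens), read by microscopy, with a stated time of 96 h; on this read-out higher numbers stand for an effect only at larger amounts of compound and lower numbers for an effect already at smaller amounts.
Compound 2, `CCN(CC)CCNC(=O)c1ccc(C(CC)(CC)c2ccc(OCC(=O)C(C)(C)C)c(C)c2)n1CC`, gives 91 nM in this assay.
Compound 3, `CCn1c(C(=O)NCCN)ccc1C(CC)(CC)c1ccc(OCC(=O)C(C)(C)C)c(C)c1`, gives 120 nM in this assay.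

Among the three measured compounds, compound 2 gives the smallest number, but the gap to compound 3 is within the scatter (a 1.3-fold higher number from compound 2 to compound 3 (0.12 log units; within the scatter)), so those two cannot be separated; only compound 1 stands clearly apart (a 6.5-fold lower number from compound 1 to compound 2 (0.81 log units; beyond the scatter)). Compound 4, `CCn1c(C(=O)N(C)CCC#N)ccc1C(CC)(CC)c1ccc(OCC(=O)C(C)(C)C)c(C)c1`, differs from compound 2 in one place: (2-cyanoethyl)(methyl)amino in place of (2-(diethylamino)ethyl)amino on a carbonyl carbon.

Within the data shown here, no measured step removes the amide hydrogen or brings in a nitrile, so the guidance is indirect. The steps of a 6.5-fold lower number from compound 1 to compound 2 (0.81 log units; beyond the scatter) and a 4.9-fold lower number from compound 1 to compound 3 (0.69 log units; beyond the scatter) show that the group on the amide nitrogen can shift the number well beyond the scatter, whereas a 1.3-fold higher number from compound 2 to compound 3 (0.12 log units; within the scatter) shows that swapping one amine-bearing chain for another barely matters. Compound 4 keeps neither chain, so a modest rise is expected. The expected step is a 2.2-fold higher number from compound 2 to compound 4 (0.34 log units; beyond the scatter). Compound 4 is expected to give 200 nM, within a range from 60 nM to 700 nM.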

Compound 4, half-maximal effective concentration: 9800 nM
Beside the measured number, compound 4's estimate is 49-fold (1.69 log units) below it; measured number above the stated range.
By their numbers in this assay, from the lowest: compounds 2 and 3 (each within the scatter of the next); then compound 1; then compound 4.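

Among these compounds, this position can move the number much further than compounds 1 to 3 showed: in this assay, placing (2-cyanoethyl)(methyl)amino on the carbonyl carbon gives the largest steps so far (a 110-fold higher number from compound 2 to compound 4 (2.03 log units; beyond the scatter)) and (an 82-fold higher number from compound 3 to compound 4 (1.91 log units; beyond the scatter)). The step from the (1-(methoxycarbonyl)-2-methylbutyl)amino compound is also large (a 17-fold higher number from compound 1 to compound 4 (1.22 log units; beyond the scatter)), so compound 4 stands clearly apart from all three earlier compounds. Among these four compounds, only compound 4 has no hydrogen-bond donor in this group and a triple bond outside aromatic rings.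

The change alters several features at once, so a (2-cyanoethyl)amino group, which keeps the amide hydrogen, and a (2-(diethylamino)ethyl)(methyl)amino group, which keeps the diethylamino end, would be needed to tell these features apart. No measurement shown here accounts for the size of this step.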